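The source may report more compounds than this note shows. Statements on the series, on what has been measured and on what is new or still open speak of the compounds shown alone.

Compound 1 `CC(=O)n1cc(/C=C(/C(=O)O)c2ccccc2)c2cc(OCc3ccccc3)ccc21` has the weaker of the two numbers in hand: in a functional assay on KB cells (Homo sapiens) for cytotoxicity, read by MTT assay, with a stated time of 72 h (a higher number here means a weaker inhibitor, a lower number a stronger inhibitor), compound 1 gives 55500 nM, while compound 2 `CC(=O)n1cc(/C=C(/C(=O)O)c2ccc(OCc3ccccc3)cc2)c2cc(OCc3ccccc3)ccc21` gives 43000 nM, a step of a 1.3-fold lower number from compound 1 to compound 2 (0.11 log units; within the scatter). Compound 3 `COc1ccccc1/C(=C\c1cn(C(C)=O)c2ccc(OCc3ccccc3)cc12)C(=O)O` differs from compound 1 by methoxy in place of hydrogen on an aromatic carbon, placed on the same six-membered ring that carried the added group in compound 2. Within the data shown here, the single step that bears on it, from compound 1 to compound 2, stayed within the scatter, so no shift beyond the scatter is expected in this assay here either, and the step from compound 1 to compound 3 is estimated as a 1.1-fold lower number from compound 1 to compound 3 (0.05 log units; within the scatter). For compound 3 the expected value is 50000 nM, with a range from 20000 nM to 130000 nM.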

Compound 3, half-maximal inhibitory concentration: > 100000 nM
Compound 3 gave a limit, no number; the forecaster's own chance of this, stated with the estimate: 15%; middle value at least 2.0-fold (0.30 log units) from the limit.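

In this assay the reading for compound 3 is a limit, not a number: the limit of > 100000 nM in this assay, at which 1 of the 3 values shown sits. Methoxy on an aromatic carbon, ortho to a large group, gives an at least 1.8-fold higher number from compound 1 to compound 3 (0.25 log units; that floor lies within the scatter), so this change at this position shows no gain, although that floor alone does not separate the two compounds. As far as these compounds go, the true size of the step stays unknown, with no upper bound on it.

Still open, from the compounds shown here alone, is whether a hydroxyl or an amine in this place, or a longer chain such as ethoxy, would give a measurable number in this assay.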